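Working notes on the aryl replacement step in the series

The compounds below may be only part of what the source reports. "The series", "measured", "known", "first", "only" and "open" are said of these compounds alone.

Two compounds of the series have numbers in a functional assay on HepG2 cells (Homo sapiens) for inhibition, read by MTT assay, with a stated time of 24 h (on this read-out higher numbers stand for weaker inhibition and lower numbers for stronger inhibition), so far. Compound 1 `CCOC(=O)c1c(C)[nH]c(=O)c(C#N)c1-c1ccc([N+](=O)[O-])cc1` gives 21700 nM in this assay. Among the measured compounds shown here, compound 2 `CCOC(=O)c1c(C)[nH]c(=O)c(C#N)c1-c1ccc(Br)cc1` gives 65500 nM in this assay and so stands at the highest of the two numbers; the only measured step, a 3.0-fold higher number from compound 1 to compound 2 (0.48 log units; beyond the scatter), is modest though beyond the scatter. Compound 3 `CCOC(=O)c1c(C)[nH]c(=O)c(C#N)c1-c1cccs1` differs from compound 2 by thiophen-2-yl in place of 4-bromophenyl on an aromatic carbon. For the measured compounds named here, no measured step bears directly on this change: the single step in hand exchanges one group while keeping the ring, and it was only modest. The step of a 1.3-fold lower number from compound 2 to compound 3 (0.12 log units; within the scatter) is therefore expected to stay within the scatter, with no clear direction. Compound 3 is estimated at 50000 nM in this assay, with a range from 15000 nM to 160000 nM.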

Compound 3, half-maximal inhibitory concentration: 74100 nM
For compound 3 the middle estimate is 1.5-fold (0.17 log units) below the measured one; low and high end bracket the measured number.
By their numbers in this assay, from the lowest: compound 1; then compounds 2 and 3 (each within the scatter of the next).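

In this assay the exchange of the whole aryl group gives a 1.1-fold higher number from compound 2 to compound 3 (0.05 log units; within the scatter) and so leaves the number in place: at this carbon, opposite the ring nitrogen, the five-membered thiophen-2-yl ring and the six-membered 4-bromophenyl ring cannot be told apart. Among the compounds shown here, the one step beyond the scatter at this position remains the exchange of nitro for bromo on the phenyl ring, a 3.0-fold higher number from compound 1 to compound 2 (0.48 log units; beyond the scatter) in the same assay, so ring size and the sulfur atom show no effect on this read-out in this pair. No supporting data bear on why the two aryl groups read alike.

As far as these compounds go, it stays open whether an amine or a carboxylic acid on the phenyl ring would separate further from compound 1 at 21700 nM in either direction. From the compounds shown here alone, the effect of a saturated ring or a longer chain at this carbon also remains open.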